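A Fluoro-to-Bromo Swap on Compound 2

The compounds below may be only part of what the source reports. "The series", "measured", "known", "first", "only" and "open" are said of these compounds alone.

Among the measured compounds shown here, in a functional assay on HeLa cells (Homo sapiens) for inhibition, read by MTT assay, with a stated time of 48 h (on this read-out higher numbers stand for weaker inhibition of growth and lower numbers for stronger inhibition of growth), compound 2 (`Cn1cc(C2CC(c3ccc(F)cc3)=NN2C(=O)c2cccnc2)c2cc(Br)ccc21`) gives 630 nM as the lower of the two numbers known so far. Compound 1 (`Cn1cc(C2CC(c3ccccc3)=NN2C(=O)c2ccc(Cl)nc2)c2ccccc21`) gives 8310 nM and that gap lies beyond the scatter of repeated measurements. Compound 3 (`Cn1cc(C2CC(c3ccc(Br)cc3)=NN2C(=O)c2cccnc2)c2cc(Br)ccc21`) has not yet been tested. It is compound 2 with a single change: bromo in place of fluoro on an aromatic carbon. For the measured compounds named here, no two measured compounds differ in only one place, so the data offer no direct guide to this swap. The safest expectation in this assay is therefore no step beyond the scatter, in either direction. The expected change is a 1.1-fold lower number from compound 2 to compound 3 (0.02 log units; within the scatter) and this estimate is deliberately modest. For compound 3 the estimated value is 600 nM with 230 nM to 1500 nM as the expected range.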

Compound 3, concentration for 50% growth inhibition: > 10000 nM
Compound 3 gave a limit, no number; the forecaster's own chance of this, stated with the estimate: 3%; middle value at least 16-fold (1.22 log units) away from the limit.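

Among the compounds shown here, the earlier compounds offered no pair differing in one place, so this is the only direct look at the group on this ring: in this assay, going from 4-fluorophenyl to 4-bromophenyl gives an at least 15-fold higher number from compound 2 to compound 3 (1.20 log units; beyond the scatter). This place, on an aromatic carbon para to a large group, is therefore not indifferent to what it carries: exchanging one heavy atom for another, with no hydrogen-bond donor, acceptor or charge involved, costs most of the growth inhibition. The reading for compound 3 is a limit of the assay and not a number, and the step gives only a minimum size: the limit of > 10000 nM in this assay, at which 1 of the 3 values shown sits.

From the compounds shown here alone, whether chloro, methyl, methoxy or an amine at this place would be tolerated stays open. One pair also cannot show whether the swap would act the same way with other groups elsewhere on the shared core.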